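A Methoxymethyl Amide Follows the Pyridin-4-yl Compound

A few compounds are considered here, and "the series" means these few. Any claim that something is new, unique, unknown or untested is made for them only; others in the source may bear on it.

For the measured compounds named here, in a functional assay on KB cells (Homo sapiens) for antiproliferative activity, read by sulforhodamine B assay, with a stated time of 3 days (on this read-out higher numbers stand for weaker inhibition of growth and lower numbers for stronger inhibition of growth), compound 3 `O=C(Nc1cccc(Nc2ncc(F)c(Nc3ccc(F)cc3)n2)c1)c1ccncc1` gives 5280 nM as the only true number so far. Compound 1 `O=C(Nc1nccs1)c1cccc(Nc2ncc(F)c(Nc3ccc(F)cc3)n2)c1` is reported as > 10000 nM and this is a limit of the assay. Compound 2 `CN(C)c1ccc(C(=O)Nc2cccc(Nc3ncc(F)c(Nc4ccc(F)cc4)n3)c2)cc1` is reported as > 10000 nM and this too is a limit. Compound 4 `COCC(=O)Nc1cccc(Nc2ncc(F)c(Nc3ccc(F)cc3)n2)c1` is reached from compound 3 by methoxymethyl in place of pyridin-4-yl on a carbonyl carbon so that methoxymethyl stands in place of pyridin-4-yl on a carbonyl carbon. The nearest measured guide, at that same carbonyl carbon, is an at least 1.8-fold lower number from compound 2 to compound 3 (0.27 log units; that floor lies within the scatter) with pyridin-4-yl in place of 4-(dimethylamino)phenyl. A less direct guide is an at least 1.8-fold lower number from compound 1 to compound 3 (0.27 log units; that floor lies within the scatter) where the amide itself is changed. Both are floors within the scatter, so neither sets a size for the new step, and no clear direction is expected. The expected change is a 1.1-fold higher number from compound 3 to compound 4 (0.06 log units; within the scatter) and so no move beyond the scatter is anticipated. In this assay the estimate for compound 4 is 6000 nM with an expected range from 2000 nM to 15000 nM. A limit of the assay in place of a number would be unsurprising for compound 4.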

Compound 4, concentration for 50% growth inhibition: 6250 nM
The estimate for compound 4 lay 1.0-fold (0.02 log units) below the measured number; the range from low to high includes it.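

In this assay, for the compounds shown here, the change at this carbonyl carbon gives a 1.2-fold higher number from compound 3 to compound 4 (0.07 log units; within the scatter) and so leaves compound 4 level with compound 3, which is the first comparison here between two true numbers. It shows that the six-membered aromatic ring of pyridin-4-yl is not required for a measurable number at this place, since methoxymethyl, which has no ring, does as well, something compound 3 alone could not show. The other two steps, an at least 1.6-fold lower number from compound 2 to compound 4 (0.20 log units; that floor lies within the scatter) and an at least 1.6-fold lower number from compound 1 to compound 4 (0.20 log units; that floor lies within the scatter), are floors that set no size, and the values behind them are limits of the assay: the limit of > 10000 nM in this assay, at which 2 of the 4 values shown sit.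

Going by these compounds, it remains open whether an amine, a carboxylic acid or a longer chain on this carbonyl carbon would move the number beyond the scatter. On these data alone, with only compound 3 and compound 4 giving true numbers, it is also open whether any group at this place gives clearly stronger inhibition of growth.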